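A few compounds are considered here, and "the series" means these few. Any claim that something is new, unique, unknown or untested is made for them only; others in the source may bear on it.

Going by the values given here, in a functional assay on PANC-1 cells (Homo sapiens) for inhibition, read by MTT assay, with a stated time of 24 h (on this read-out higher numbers stand for weaker inhibition and lower numbers for stronger inhibition), three compounds sharing one core have numbers so far. Compound 1 `CC1(C)[C@H]2CC[C@]1(C)N(Cc1cn(-c3cccc(F)c3)nn1)C(=O)C2`, with 3-fluorophenyl, gives 220 nM. Compound 2 `CC1(C)[C@H]2CC[C@]1(C)N(Cc1cn(-c3ccc(O)cc3)nn1)C(=O)C2`, with 4-hydroxyphenyl, gives 100 nM. Compound 3 `CC1(C)[C@H]2CC[C@]1(C)N(Cc1cn(-c3ccc(Cl)cc3)nn1)C(=O)C2`, with 4-chlorophenyl, gives 440 nM. Two steps place compound 3: a 2.0-fold higher number from compound 1 to compound 3 (0.30 log units; within the scatter), and a 4.4-fold higher number from compound 2 to compound 3 (0.64 log units; beyond the scatter). Compound 4 `COc1ccc(-n2cc(CN3C(=O)C[C@@H]4CC[C@@]3(C)C4(C)C)nn2)cc1` has methoxy in place of chloro on an aromatic carbon, para to a large group (methoxy in place of chloro on an aromatic carbon). The nearest guide is compound 2, since its hydroxy also joins the ring through oxygen and sits at that same place, with the modest step of a 4.4-fold higher number from compound 2 to compound 3 (0.64 log units; beyond the scatter) separating it from the chloro compound. A similar drop, no larger, is therefore expected. The expected step is a 2.2-fold lower number from compound 3 to compound 4 (0.34 log units; beyond the scatter). For compound 4 the estimated value is 200 nM, with an expected range of 80 nM to 500 nM.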

Compound 4, half-maximal inhibitory concentration: 330 nM
Beside the measured number, compound 4's estimate is 1.7-fold (0.22 log units) below it; the range from low to high includes it.
By their numbers in this assay, from the lowest: compound 2; then compounds 1, 4 and 3 (each within the scatter of the next).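

Putting a methyl on the oxygen of the hydroxy group gives a 3.3-fold higher number from compound 2 to compound 4 (0.52 log units; beyond the scatter), so an oxygen at this place does not by itself bring the lower number of compound 2. Methoxy in place of chloro gives a 1.3-fold lower number from compound 3 to compound 4 (0.12 log units; within the scatter), and changing the 3-fluorophenyl group to 4-methoxyphenyl gives a 1.5-fold higher number from compound 1 to compound 4 (0.18 log units; within the scatter). Among these four, only compound 2 stands apart.

Nothing available explains this gap. As far as these compounds go, whether an amine at this place, with hydrogens on its nitrogen, would match compound 2 remains open.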